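The source may report more compounds than this note shows. Statements on the series, on what has been measured and on what is new or still open speak of the compounds shown alone.

Three compounds share one core and are compared in an assay on blood for inhibition of C-X-C chemokine receptor type 3 (Homo sapiens), with a stated time of 30 min; on this read-out lower numbers stand for stronger inhibition and higher numbers for weaker inhibition. Compound 1 `Cc1ncc(-c2nc(C(F)(F)F)sc2N2CCN(C(=O)Cn3cnc4cccnc43)[C@H](C)C2)cn1` gives 104 nM in this assay. Compound 2 `Cc1nc(C)n(CC(=O)N2CCN(c3sc(C(F)(F)F)nc3-c3cnc(OC4CCC4)nc3)C[C@H]2C)n1` gives 306 nM. Compound 3 `Cc1ncc(-c2nc(C(F)(F)F)sc2N2CCN(C(=O)Cn3nc(C)nc3C)[C@H](C)C2)cn1` gives 610 nM, the highest of the three numbers. The step of a 5.9-fold higher number from compound 1 to compound 3 (0.77 log units; beyond the scatter) lies beyond the scatter, whereas the step of a 2.0-fold higher number from compound 2 to compound 3 (0.30 log units; within the scatter) stays within it.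

Compound 4 `Cc1nc(C)n(CC(=O)N2CCN(c3sc(C(F)(F)F)nc3-c3cnc(C(C)(C)C)nc3)C[C@H]2C)n1` differs from compound 3 in one place: tert-butyl in place of methyl on an aromatic carbon. For the measured compounds named here, of the measured steps, only the step from compound 2 to compound 3 changes the same aromatic carbon of the six-membered ring, and there a larger group in place of methyl went with a number that was lower by an amount within the scatter. Because the step of a 2.0-fold higher number from compound 2 to compound 3 (0.30 log units; within the scatter) stayed within the scatter, compound 4 is expected to show at most a small move, a 1.7-fold lower number from compound 3 to compound 4 (0.24 log units; within the scatter), toward a lower number. The estimate for compound 4 in this assay is 350 nM, with a range from 150 nM to 800 nM.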

Compound 4, half-maximal inhibitory concentration: 1160 nM
Compound 4: middle estimate off by 3.3-fold (0.52 log units), on the low side; the measured number lies above the stated range.
By their numbers in this assay, from the lowest: compound 1; then compounds 2, 3 and 4 (each within the scatter of the next, the first and the last beyond it).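

At the aromatic carbon between two ring nitrogen atoms, the change from 2-methylpyrimidin-5-yl to 2-(tert-butyl)pyrimidin-5-yl gives a 1.9-fold higher number from compound 3 to compound 4 (0.28 log units; within the scatter) in this assay, so tert-butyl and methyl cannot be told apart at this position. What is new is that this carbon can separate two groups: tert-butyl in place of cyclobutyloxy gives a 3.8-fold higher number from compound 2 to compound 4 (0.58 log units; beyond the scatter) and so goes beyond the scatter, which a 2.0-fold higher number from compound 2 to compound 3 (0.30 log units; within the scatter) did not, and a larger group here therefore does not by itself go with a lower number. No supporting measurement is available to explain this result.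

The compounds shown leave open whether an amine or a carboxylic acid on this carbon would give a number apart from these three. They also leave open whether these steps would hold with the group that compound 1 carries on the saturated chain carbon bound to the carbonyl carbon.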